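Swapping a propyl chain for iodine on the aniline ring

A few compounds are considered here, and "the series" means these few. Any claim that something is new, unique, unknown or untested is made for them only; others in the source may bear on it.

The three measured compounds share one core and differ only in the group on the aniline ring. Compound 1 `O=C1C(Nc2ccc(I)cc2)=CC(=O)c2c1nc1n2[C@H]2OC[C@@H](O)[C@H]2OC1` carries iodo and gives 4010 nM in a functional assay on HeLa cells (Homo sapiens) for inhibition, read by sulforhodamine B assay; a lower number here means a stronger inhibitor, a higher number a weaker inhibitor. Compound 3 `O=C1C(Nc2ccc(Br)cc2)=CC(=O)c2c1nc1n2[C@H]2OC[C@@H](O)[C@H]2OC1` carries bromo and gives 5220 nM; the step of a 1.3-fold higher number from compound 1 to compound 3 (0.11 log units; within the scatter) shows that this exchange of halogens made no difference worth noting. Compound 2 `CCCc1ccc(NC2=CC(=O)c3nc4n(c3C2=O)[C@H]2OC[C@@H](O)[C@H]2OC4)cc1` carries a propyl chain and gives 4990 nM, a number that sits among the others, within the scatter of both compound 1 and compound 3.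

Compound 4 `O=C1C=C(Nc2ccc(I)cc2)C(=O)c2c1nc1n2[C@H]2OC[C@@H](O)[C@H]2OC1` is the next case. The change from compound 2 to compound 4 is iodo in place of propyl on an aromatic carbon. Among the measured compounds shown here, compound 1 and compound 3 already show that two different halogens in this position give numbers close to that of compound 2, so the halogen versus chain exchange has not moved the numbers so far. On that basis compound 4 is expected to land near its neighbours, with the step of a 1.1-fold lower number from compound 2 to compound 4 (0.04 log units; within the scatter) expected to stay within the scatter. The estimate for compound 4 is 4500 nM, with a range from 2000 nM to 10000 nM.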

Compound 4, half-maximal inhibitory concentration: 4070 nM
The estimate for compound 4 lay 1.1-fold (0.04 log units) above the measured number; low and high end bracket the measured number.
By their numbers in this assay, from the lowest: compounds 1, 4, 2 and 3 (each within the scatter of the next).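

In this assay, among the compounds shown here, the step of a 1.2-fold lower number from compound 2 to compound 4 (0.09 log units; within the scatter) gives the first direct exchange of the propyl chain for a halogen; until now, compound 2 had no single-change link to another compound. It shows that, on an aromatic carbon para to a large group, 4-propylphenyl and 4-iodophenyl cannot be told apart in this assay, even though three carbons leave and one iodine enters. No measurement here explains why the two groups give such similar numbers.

The compounds shown leave open whether this position tolerates any group or only groups like these two, since all of them carry a halogen or a short carbon chain. An amine, a carboxylic acid or a much longer chain in the same place could still shift the number well beyond the scatter.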